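This account rests on a few compounds, and the source may have more. Where it says the series, first, only, none or still open, it means among the compounds named here.

Measured compounds:
Compound 1 `COc1ccc(/C=C2\CCC/C(=C\c3ccccc3[N+](=O)[O-])C2=O)cc1` in a functional assay on L1210 cells (Mus musculus) for cytotoxicity, with a stated time of 48 h (on this read-out lower numbers stand for stronger inhibition and higher numbers for weaker inhibition), gives 42400 nM.
Compound 2 `CN(C)c1ccc(/C=C2\CCC/C(=C\c3cccc([N+](=O)[O-])c3)C2=O)cc1` gives 156000 nM.
Compound 3 `CN(C)c1ccc(/C=C2\CCC/C(=C\c3ccc([N+](=O)[O-])cc3)C2=O)cc1` reaches only the limit of this assay, > 500000 nM.

Among the two numbers shown, compound 1 stands lowest, with compound 2 giving the higher number. Compound 4 `O=C1/C(=C/c2ccccc2)CCC/C1=C\c1ccccc1[N+](=O)[O-]` has not yet been measured. It differs from compound 1 in one place: hydrogen in place of methoxy on an aromatic carbon, that is, 4-methoxyphenyl to phenyl. Within the data shown here, the only measured step, an at least 3.2-fold higher number from compound 2 to compound 3 (0.50 log units; beyond the scatter), concerns the nitrophenyl ring, not the methoxy, so no measured step bears directly on this change. With the methoxy removed and nothing else altered, compound 4 is expected to give 70000 nM, in the range 25000 nM to 200000 nM. Compound 4 is thus expected to show the step of a 1.7-fold higher number from compound 1 to compound 4 (0.22 log units; within the scatter), a small rise at most.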

Compound 4, half-maximal inhibitory concentration: 4840 nM
Compound 4: the middle estimate sits 14-fold (1.16 log units) above what was measured; the measured number lies below the stated range.
By their numbers in this assay, from the lowest: compound 4; then compound 1; then compound 2. At a limit, above all of these: compound 3.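

In this assay, among these compounds, hydrogen in place of methoxy, on an aromatic carbon para to a large group, gives an 8.8-fold lower number from compound 1 to compound 4 (0.94 log units; beyond the scatter), so this position, which no earlier step touched, responds clearly to the change. The step is read with the rest of compound 1 unchanged, and it holds for this one pair only. Nothing measured among the compounds shown bears on the cause of this step.

Going by these compounds, how a chlorine atom, a hydroxyl group or a longer ethoxy chain would read at this position remains open. So does whether the step carries over when 3-nitrophenyl or 4-nitrophenyl is present.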